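The source may report more compounds than this note shows. Statements on the series, on what has been measured and on what is new or still open speak of the compounds shown alone.

Compound 2 `Nc1nnc(SCc2cc(=O)c3cc(Cl)ccc3o2)s1` carries a 5-amino-1,3,4-thiadiazol-2-yl group on a sulfur. In a functional assay on HEp-2 cells (Homo sapiens) for cytotoxicity, read by MTT assay, with a stated time of 72 h (a lower number here means a stronger inhibitor, a higher number a weaker inhibitor), compound 2 reaches only the limit of the assay, > 25000 nM. Compound 1 `Cc1nnc(SCc2cc(=O)c3cc(Cl)ccc3o2)o1` differs from it by 5-methyl-1,3,4-oxadiazol-2-yl in place of 5-amino-1,3,4-thiadiazol-2-yl on a sulfur. In this assay compound 1 likewise stops at a limit, > 25000 nM. Compound 3 `Cc1ccc2oc(CSc3nnc(N)s3)cc(=O)c2c1` differs from compound 2 by methyl in place of chloro on an aromatic carbon, which is how the two cores differ. In this assay compound 3 also gives only a limit, > 25000 nM. Neither a step that the two limits leave unreadable from compound 2 to compound 1 nor a step that the two limits leave unreadable from compound 2 to compound 3 can be sized, since (the limit of > 25000 nM in this assay, at which 3 of the 3 values shown sit). Compound 4 `Cc1ccc2oc(CSc3nnc(C)o3)cc(=O)c2c1` is not yet measured; it differs from compound 3 by 5-methyl-1,3,4-oxadiazol-2-yl in place of 5-amino-1,3,4-thiadiazol-2-yl on a sulfur, the same change at the same place as between compound 2 and compound 1. Because the earlier step that the two limits leave unreadable from compound 2 to compound 1 is unreadable, the expected step is a step that the limit leaves unreadable from compound 3 to compound 4, and compound 4 is estimated at 30000 nM, most likely again a limit.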

Compound 4, half-maximal inhibitory concentration: > 25000 nM
Compound 4 ended at the assay's limit; the forecaster's own chance of this, stated with the estimate: 85%; the middle value lies beyond the limit too.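

Going by these compounds alone, no step from compound 3 to compound 4 or from compound 1 to compound 4 can be read, since each result is only a limit: the limit of > 25000 nM in this assay, at which 4 of the 4 values shown sit. The compounds shown leave open whether either change alters the activity in this assay at all.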